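A few compounds are considered here, and "the series" means these few. Any claim that something is new, unique, unknown or untested is made for them only; others in the source may bear on it.

Of the compounds shown here, two with a shared core have been measured in an ADME assay for protein binding, using equilibrium dialysis, at pH 7.4, tested at 2 uM; on this read-out higher numbers stand for a larger free fraction and lower numbers for a smaller free fraction. Compound 1 (`CC(C)N(c1cc(C#CC(C)(C)C)sc1C(=O)O)C(=O)[C@H]1CC[C@H](C)CC1`) gives 0.06, and compound 2 (`CC(C)(C)C#Cc1cc(N(C(=O)[C@H]2CC[C@H](C)CC2)[C@H]2C[C@@H](Oc3cccnc3)C2)c(C(=O)O)s1`) gives 0.04, so compound 2 stands level with compound 1 within the usual scatter of repeated measurements. Compound 3 (`CON=C1CCC(N(c2cc(C#CC(C)(C)C)sc2C(=O)O)C(=O)[C@H]2CC[C@H](C)CC2)CC1`) has not yet been measured. It differs from compound 2 on an amide-type nitrogen: a group of 9 heavy atoms (7 carbon, 1 nitrogen, 1 oxygen; one six-membered non-aromatic ring of carbon only) in place of a group of 11 heavy atoms (9 carbon, 1 nitrogen, 1 oxygen; one four-membered non-aromatic ring of carbon only, one six-membered aromatic ring with 1 hetero atom), on an amide-type nitrogen.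

Among the measured compounds shown here, only one measured step bears on this change. It is a 1.5-fold lower number from compound 1 to compound 2 (0.18 log units; within the scatter), with 3-((pyridin-3-yl)oxy)cyclobutyl taking the place of isopropyl on the same amide-type nitrogen. Two quite different groups at this place therefore gave values that cannot be told apart. The group entering compound 3 has not been seen in any measured compound, and two values are a thin basis for a forecast. Even so, no step beyond the scatter is expected in this assay, and the expected size is a 1.3-fold higher number from compound 2 to compound 3 (0.10 log units; within the scatter). The estimate for compound 3 is 0.05, with an expected range from 0.025 to 0.1.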

Compound 3, unbound fraction: 0.07
Estimate against measurement, compound 3: 1.4-fold (0.15 log units) below; the measured number falls inside the stated range.
By their numbers in this assay, from the lowest: compounds 2, 1 and 3 (each within the scatter of the next).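

In this assay a third group on the amide-type nitrogen, this one with a six-membered non-aromatic ring of carbon only and a double bond outside aromatic rings, again gives no step beyond the scatter. Measured against the two earlier groups, the change is a 1.8-fold higher number from compound 2 to compound 3 (0.24 log units; within the scatter) and a 1.2-fold higher number from compound 1 to compound 3 (0.07 log units; within the scatter), so isopropyl, 3-((pyridin-3-yl)oxy)cyclobutyl and this new group cannot be told apart in this assay, even though they differ in size and ring content, and the earlier pair alone could not show that this holds for a third group. No other measurement is available that could explain these numbers.

All three groups carry no net charge, so the compounds shown leave open whether a group at this place bearing an amine or a second carboxylic acid would also stay within the scatter. They also leave open whether the same holds with a different group in place of the 4-methylcyclohexane carbonyl on that nitrogen, since all three compounds share that part.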